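This account rests on a few compounds, and the source may have more. Where it says the series, first, only, none or still open, it means among the compounds named here.

Measured in a functional assay on K562 cells (Homo sapiens) for cytotoxicity, read by trypan blue exclusion, with a stated time of 96 h; on this read-out higher numbers stand for weaker inhibition and lower numbers for stronger inhibition:
- Compound 1 `COC(=O)C(Nc1cc(CS(=O)(=O)/C=C/c2c(OC)cc(OC)cc2OC)ccc1OC)c1ccccc1`: 30 nM
- Compound 2 `COC(=O)C(Nc1cc(CS(=O)(=O)/C=C/c2c(OC)cc(OC)cc2OC)ccc1OC)c1ccc(Br)cc1`: 200 nM
- Compound 3 `COc1cc(OC)c(/C=C/S(=O)(=O)Cc2ccc(OC)c(NC(F)(F)C(=O)O)c2)c(OC)c1`: 150 nM

Compound 3, at 150 nM, sits level with compound 2 within the scatter, as a 1.3-fold lower number from compound 2 to compound 3 (0.12 log units; within the scatter) shows, and both lie above compound 1, as a 5.0-fold higher number from compound 1 to compound 3 (0.70 log units; beyond the scatter) shows. Compound 4 `COc1cc(OC)c(/C=C/S(=O)(=O)Cc2ccc(OC)c(NC(C(=O)O)c3ccc(Br)cc3)c2)c(OC)c1` differs from compound 3 by one change: (4-bromophenyl)(carboxy)methyl in place of carboxy(difluoro)methyl on a nitrogen on an aromatic ring. The group that enters keeps the carboxy and adds the 4-bromophenyl also found in compound 2. Bromo on the aromatic carbon gave a modest step, a 6.7-fold higher number from compound 1 to compound 2 (0.82 log units; beyond the scatter), but compound 3 already stands level with compound 2, so that step should not simply be added again. Within the data shown here, no measured pair sets methoxycarbonyl directly against carboxy on an otherwise unchanged compound, which leaves the forecast uncertain. Given a 1.3-fold lower number from compound 2 to compound 3 (0.12 log units; within the scatter), the expected step in this assay is small, a 1.3-fold higher number from compound 3 to compound 4 (0.12 log units; within the scatter), and is not expected to go beyond the scatter. For compound 4 the estimated value is 200 nM, with an expected range of 70 nM to 600 nM.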

Compound 4, half-maximal inhibitory concentration: 200 nM
Compound 4: the middle estimate sits on the measured number at the digits printed, within the range that was stated.
By their numbers in this assay, from the lowest: compound 1; then compounds 3, 2 and 4 (each within the scatter of the next).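

In this assay, swapping carboxy(difluoro)methyl for (4-bromophenyl)(carboxy)methyl on a nitrogen on an aromatic ring adds one six-membered aromatic ring of carbon only, yet the number stays within the scatter (a 1.3-fold higher number from compound 3 to compound 4 (0.12 log units; within the scatter)). Among these compounds, compounds 2 and 4 provide the first direct comparison of methoxycarbonyl with carboxy, and this exchange shows no change (no change at the digits printed from compound 2 to compound 4 (within the scatter)). Compound 4 remains separated from compound 1 by a step beyond the scatter (a 6.7-fold higher number from compound 1 to compound 4 (0.82 log units; beyond the scatter)), so compound 1 stays apart from the other three compounds at this position.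

The compounds shown do not tell whether carboxy would read the same without the bromo, or how a primary amide in place of carboxy or a chloro in place of bromo would read. No evidence is available to explain these results.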